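A few compounds are considered here, and "the series" means these few. Any claim that something is new, unique, unknown or untested is made for them only; others in the source may bear on it.

Three compounds define the range seen so far in an in vitro assay on Sf9 cells for inhibition of Rho-associated protein kinase 2 (Homo sapiens), read by TR-FRET, with a stated time of 25 min; on this read-out lower numbers stand for stronger inhibition and higher numbers for weaker inhibition. Compound 1 `CN(C)CCNc1nc([C@@H]2CNC[C@H]2c2ccc(F)cc2)nc2ccc(-c3cn[nH]c3)cc12` gives 371 nM in this assay, the highest number of the three and therefore the weakest inhibition. Compound 2 `NC(c1ccc(Cl)cc1)c1nc2ccc(-c3cn[nH]c3)cc2c(=O)[nH]1` gives 10 nM in this assay, and compound 3 `COc1ccc([C@@H]2CN(Cc3ccccc3)C[C@H]2c2nc3ccc(-c4cn[nH]c4)cc3c(=O)[nH]2)cc1` gives 88 nM in this assay. Set against compound 3, compound 1 is beyond the usual scatter, and set against compound 2 the distance is far wider; compound 1 is the weakest of the three by a clear margin, with compound 2 the strongest.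

The next compound, compound 4 `Fc1ccc([C@@H]2CNC[C@H]2c2nc(N3CCC3)c3cc(-c4cn[nH]c4)ccc3n2)cc1`, is compound 1 altered in one place: azetidin-1-yl in place of (2-(dimethylamino)ethyl)amino on an aromatic carbon. The chain that carries a hydrogen-bond donor and two acceptors gives way to a small ring carrying one acceptor and no donor. For the measured compounds named here, no measured pair among compounds 1 to 3 shows this kind of swap, so there is no step to lean on, and the two values of compounds 2 and 3 only tell that other arrangements of the shared core reach lower numbers.

Without a guide, the change is expected to move this assay only modestly, most likely a little toward weaker inhibition, so compound 4 is estimated at 500 nM, within 150 nM to 1800 nM, a step of a 1.3-fold higher number from compound 1 to compound 4 (0.13 log units; within the scatter).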

Compound 4, half-maximal inhibitory concentration: 71 nM
The estimate for compound 4 lay 7.0-fold (0.85 log units) above the measured number; measured number below the stated range.
By their numbers in this assay, from the lowest: compound 2; then compounds 4 and 3 (each within the scatter of the next); then compound 1.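

The carbon next to the ring nitrogen proves to be a place where the substituent matters: in this assay the swap of (2-(dimethylamino)ethyl)amino for azetidin-1-yl gives a 5.2-fold lower number from compound 1 to compound 4 (0.72 log units; beyond the scatter) and so stronger inhibition. The group that leaves is an open chain with a hydrogen-bond donor, while the group that enters is a smaller four-membered ring with no such donor, so on this core neither the chain nor its donor is required to reach the stronger inhibition seen here. Nothing measured here explains why the number falls, and a single step changes ring, size and donor count all at once, so the gain cannot be assigned to any one of them.

Still open, on these data alone, is which of those differences counts, and a plain dimethylamino group or a five-membered pyrrolidin-1-yl ring on the same carbon would begin to separate them. For the compounds shown here, also open is whether a longer chain ending in an amine behaves like the one in compound 1, and whether the same swap gives a similar step on other versions of the shared core.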